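Metabolic stability notes: amide side-chain swap, compound 2 to 4

The compounds below may be only part of what the source reports. "The series", "measured", "known", "first", "only" and "open" are said of these compounds alone.

Measured compounds in an ADME assay on microsomes from liver (Mus musculus) for metabolic stability, with a stated time of 10 min; a higher number here means that more of the compound is left, a lower number that less of the compound is left:
- compound 1, `C[C@]1(C(=O)O)CC[C@H](C(=O)N2CC[C@](c3ccc(C(F)(C(F)(F)F)C(F)(F)F)cc3)(S(=O)(=O)c3ccc(F)cc3)C2)CC1`: 93%
- compound 2, `CC[C@]1(C(=O)O)CC[C@H](C(=O)N2CC[C@](c3ccc(C(F)(C(F)(F)F)C(F)(F)F)cc3)(S(=O)(=O)c3ccc(F)cc3)C2)CC1`: "not determined" (no result reported)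
- compound 3, `O=C(C1CCS(=O)(=O)C1)N1CC[C@](c2ccc(C(F)(C(F)(F)F)C(F)(F)F)cc2)(S(=O)(=O)c2ccc(F)cc2)C1`: 78%; 96% (2 entries)

Compound 1 and compound 3 share the core with compound 2 and differ from it only in the group on the carbonyl carbon. Compound 2 stands nowhere on the numbers: no single result is reported for it, so its own level in this assay is open. Compound 1 gives 93% and compound 3 gives 78%; 96% (2 entries); the two entries of compound 3 show how far repeat measurements of one compound spread here, see (the several entries of compound 3 in this assay, 78%; 96% (2 entries)).

Compound 4, `O=C(N1CC[C@](c2ccc(C(F)(C(F)(F)F)C(F)(F)F)cc2)(S(=O)(=O)c2ccc(F)cc2)C1)C1(CO)CCS(=O)(=O)CC1`, is not yet measured. Relative to compound 2 the change is 4-(hydroxymethyl)-1,1-dioxothian-4-yl in place of 4-carboxy-4-ethylcyclohexyl on a carbonyl carbon.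

Going by the values given here, no step between measured compounds covers this change. Since both measured neighbours of compound 2 sit high, no step beyond the scatter is expected in this assay in either direction. For compound 4 the percent remaining is estimated at 82%, with a range from 55% to 97%.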

Compound 4, percent of the compound remaining: 31%
The estimate for compound 4 lay 51 percentage points above the measured number; measured number outside the range, below it.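

In this assay the group on the carbonyl carbon proves able to move the read-out far, with a number 62 percentage points lower from compound 1 to compound 4 (beyond the scatter); the earlier compounds had shown only high numbers at this place. Compound 3 also carries a sulfur-containing ring with two oxygens here and gives 78%; 96% (2 entries), so such a ring at this place does not by itself go with a low number. The step to compound 4 is also wider than the spread of repeat entries of one compound: the several entries of compound 3 in this assay, 78%; 96% (2 entries)

The change from compound 2 cannot be read, as compound 2 has no single number. Going by these compounds, the ring, the hydroxymethyl and the loss of the carboxylic acid change together, so it stays open which of them carries the step, and whether an aminomethyl group or a carboxylic acid on the 1,1-dioxothian-4-yl ring would give a different number.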